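This account rests on a few compounds, and the source may have more. Where it says the series, first, only, none or still open, it means among the compounds named here.

Compound 1 `Cc1cc(C)cc(SCc2ccc(C(=O)Nc3ccccc3N)cc2)c1` and compound 2 `CCc1ccc(SCc2ccc(C(=O)Nc3ccccc3N)cc2)cc1` share one core and differ only in the aryl group on the sulfur. In a functional assay on HeLa cells (Homo sapiens) for inhibition, read by CCK-8 assay, with a stated time of 72 h, tested at 8 uM (on this read-out lower numbers stand for less inhibition of growth and higher numbers for more inhibition of growth at the one concentration tested), compound 1 gives 78.9%, while compound 2 gives 71%; the step of a number 7.9 percentage points lower from compound 1 to compound 2 (within the scatter) lies within the scatter. Of the two numbers, compound 2 stands lowest, with compound 1 as its nearest neighbour. Compound 3 `Nc1ccccc1NC(=O)c1ccc(CSc2ccc(Cl)cc2)cc1` takes the next step from compound 2: chloro in place of ethyl on an aromatic carbon. Within the data shown here, the one measured step that bears on this is the earlier exchange of the aryl group on the sulfur, a number 7.9 percentage points lower from compound 1 to compound 2 (within the scatter), which stayed within the scatter. Another change to the substituent on that phenyl therefore gives no ground to expect a step beyond the scatter in this assay, in either direction. Compound 3 is accordingly estimated at 71%, between 56% and 84%. The expected step of no change at the digits printed from compound 2 to compound 3 (within the scatter) is thus one within the scatter.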

Compound 3, percent growth inhibition at one concentration: 51.4%
Compound 3: the middle estimate sits 19.6 percentage points above what was measured; the measured number lies below the stated range.
By their numbers in this assay, from the lowest: compound 3; then compounds 2 and 1 (each within the scatter of the next).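

Chloro in place of ethyl on an aromatic carbon, para to a large group, gives a number 19.6 percentage points lower from compound 2 to compound 3 (beyond the scatter) in this assay, so this substituent on the aryl group can move the read-out beyond the scatter. The earlier exchange of the whole aryl group, a number 7.9 percentage points lower from compound 1 to compound 2 (within the scatter), did not show this, whereas 4-chlorophenyl in place of 3,5-dimethylphenyl on the sulfur gives a number 27.5 percentage points lower from compound 1 to compound 3 (beyond the scatter), so the aryl group on the sulfur is not interchangeable in this series. Nothing at hand gives a reason for this difference.

Going by these compounds, it remains open whether a methyl, a methoxy, a bromo or an amine on the same carbon would read like chloro or like ethyl. On these data alone, it is also open whether the lower number belongs to chloro itself or to the loss of ethyl.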